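Swapping the Fluorophenyl Arm for a Dichlorophenyl Arm

The source may hold more compounds than are shown below. What is called first, only, known or untested is meant among the compounds shown, and "the series" means these compounds.

Compound 1 `Oc1c(C(Nc2ccccn2)c2ccccc2F)ccc2cccnc12` gives 470 nM in an assay for inhibition of protein disulfide-isomerase (Homo sapiens), with a stated time of 1 h; a higher number here means a weaker inhibitor, a lower number a stronger inhibitor. Compound 2 `Cc1ccnc(NC(c2ccccc2F)c2ccc3cccnc3c2O)c1` gives 880 nM. Compound 3 `Oc1c(C(c2ccc(F)cc2)N2CCCCC2)ccc2ccoc12` gives 560 nM.

Among the compounds with values here, compound 2 carries the top figure of the three, yet every gap is inside the usual scatter, including the only single-point step, a 1.9-fold higher number from compound 1 to compound 2 (0.27 log units; within the scatter). Compound 4 `Cc1ccnc(NC(c2ccc3cccnc3c2O)c2c(Cl)cccc2Cl)c1` differs from compound 2 by 2,6-dichlorophenyl in place of 2-fluorophenyl on a saturated chain carbon bound to an aromatic carbon and a nitrogen on an aromatic ring. No measured step alters that arm: the one step shown touches a methyl elsewhere, and compound 3 differs from compound 2 in several places at once, so its number shows nothing about this swap alone. With no guidance, the expected step of a 1.2-fold lower number from compound 2 to compound 4 (0.07 log units; within the scatter) is none beyond the scatter. Compound 4 is therefore estimated at 750 nM, in the range 250 nM to 2500 nM.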

Compound 4, half-maximal inhibitory concentration: > 40000 nM
Compound 4: only a limit was reported (the forecaster's own chance of this, stated with the estimate: 5%); middle value at least 53-fold (1.72 log units) from the limit.
By their numbers in this assay, from the lowest: compounds 1, 3 and 2 (each within the scatter of the next). At a limit, above all of these: compound 4.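

This arm, on a saturated chain carbon bound to an aromatic carbon and a nitrogen on an aromatic ring, is far from free to change: in this assay, 2,6-dichlorophenyl in place of 2-fluorophenyl brings an at least 45-fold higher number from compound 2 to compound 4 (1.65 log units; beyond the scatter). Within the data shown here, the earlier compounds offered no step at this position, and their only step stayed within the scatter. The figure for compound 4 is a limit of the assay, not a number: the limit of > 40000 nM in this assay, at which 1 of the 4 values shown sits.

Which part of the change matters remains open. A 2-chlorophenyl or 2,6-difluorophenyl arm would separate the kind of halogen from the number of halogens.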